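Extending the Phenyl-Capped Chain Once More

The source may hold more compounds than are shown below. What is called first, only, known or untested is meant among the compounds shown, and "the series" means these compounds.

In a functional assay on NCI-H630 cells (Homo sapiens) for cytotoxicity, read by sulforhodamine B assay, with a stated time of 5 days (a higher number here means a weaker inhibitor, a lower number a stronger inhibitor), compound 1 (`O=C(CCCCCc1ccccc1)CC(=O)N[C@H]1CCOC1=O`) gives 24000 nM. Compound 2 (`O=C(CCCCCCc1ccccc1)CC(=O)N[C@H]1CCOC1=O`) gives 27000 nM, so the two compounds stand within the scatter of each other. Compound 3 (`O=C(CCCCCCCCc1ccccc1)CC(=O)N[C@H]1CCOC1=O`) carries phenethyl in place of phenyl on a saturated chain carbon, six bonds along the chain from a carbonyl carbon. Among the measured compounds shown here, one measured step bears on this change, a smaller chain extension: a 1.1-fold higher number from compound 1 to compound 2 (0.05 log units; within the scatter). A step beyond the scatter is therefore not expected in this assay. The expected step is a 1.1-fold lower number from compound 2 to compound 3 (0.03 log units; within the scatter). For compound 3, the estimated value is 25000 nM, within an expected range of 12000 nM to 50000 nM.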

Compound 3, half-maximal inhibitory concentration: 10000 nM
For compound 3 the middle estimate is 2.5-fold (0.40 log units) above the measured one; the measured number lies below the stated range.
By their numbers in this assay, from the lowest: compound 3; then compounds 1 and 2 (each within the scatter of the next).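

Putting phenethyl in place of phenyl on a saturated chain carbon, six bonds along the chain from a carbonyl carbon, brings the first modest gain in this assay, with a 2.7-fold lower number from compound 2 to compound 3 (0.43 log units; beyond the scatter). The earlier, smaller extension gave a 1.1-fold higher number from compound 1 to compound 2 (0.05 log units; within the scatter), so among these three compounds, added chain length does not lower the number evenly. No measurement shown explains this gain.

Still open, going by these compounds, is whether a longer chain would lower the number further, and whether a carboxylic acid in place of the phenethyl would keep the gain.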